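The source may hold more compounds than are shown below. What is called first, only, known or untested is meant among the compounds shown, and "the series" means these compounds.

Measured in an ADME assay for permeability, using PAMPA, in phosphate buffer, with a stated time of 18 h, at pH 7.4; on this read-out higher numbers stand for higher permeability and lower numbers for lower permeability:

- compound 1 `Nc1ccc2oc(N3CCN(c4ccccc4)CC3)nc2c1`: 10.3 10^-6 cm/s
- compound 2 `Nc1ccc2oc(N3CCN(c4ccc(Cl)cc4)CC3)nc2c1`: 10.6 10^-6 cm/s

Compound 2, at 10.6 10^-6 cm/s, stands level with compound 1 within the scatter. Compound 3 `COc1ccc(N2CCN(c3nc4cc(N)ccc4o3)CC2)cc1` has methoxy in place of chloro on an aromatic carbon. Among the measured compounds shown here, the only measured step that bears on this change is a 1.0-fold higher number from compound 1 to compound 2 (0.01 log units; within the scatter), with chloro in place of hydrogen on the same kind of carbon. One small step is thin evidence, and methoxy itself has not been measured here, so no step beyond the scatter is expected. The estimated step is a 1.1-fold lower number from compound 2 to compound 3 (0.05 log units; within the scatter). For compound 3 the expected value is 9.5 10^-6 cm/s, with an estimated range of 4.5 10^-6 cm/s to 18 10^-6 cm/s.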

Compound 3, apparent permeability: 10.5 10^-6 cm/s
The estimate for compound 3 lay 1.1-fold (0.04 log units) below the measured number; the measured number falls inside the stated range.
By their numbers in this assay, from the lowest: compounds 1, 3 and 2 (each within the scatter of the next).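

In this assay, methoxy in place of chloro on an aromatic carbon, para to a large group, gives a 1.0-fold lower number from compound 2 to compound 3 (0.00 log units; within the scatter), and methoxy in place of hydrogen gives a 1.0-fold higher number from compound 1 to compound 3 (0.01 log units; within the scatter). Hydrogen, chloro and methoxy, the last bringing one hydrogen-bond acceptor, thus all stand level here, which the first pair alone could not show. Nothing at hand gives a reason for this. As far as these compounds go, whether an amine or a carboxylic acid at this place would shift the number beyond the scatter stays open, as does the effect of a longer chain in place of methoxy.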